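Swapping a phenyl imidazolidinone for a trifluoromethyl pyrrolidinone

A few compounds are considered here, and "the series" means these few. Any claim that something is new, unique, unknown or untested is made for them only; others in the source may bear on it.

Of the compounds shown here, three sharing one core have been tested in a toxicity assay on HepG2 2.2.15 cells (Homo sapiens) for cytotoxicity, read by CellTiter-Glo; a higher number here means that more compound is tolerated, a lower number that less compound is tolerated. Compound 1 `O=C1CC(c2cnco2)CN1c1cnn2c1CN(C(=O)Nc1cc(F)c(F)c(F)c1)C(C1CC1)C2` gives 139000 nM. Compound 2 `O=C1NC(c2ccccc2)CN1c1cnn2c1CN(C(=O)Nc1cc(F)c(F)c(F)c1)C(C1CC1)C2` gives 38500 nM, and compound 3 `O=C1CC(c2ccc(F)cc2)CN1c1cnn2c1CN(C(=O)Nc1cc(F)c(F)c(F)c1)C(C1CC1)C2` gives 32100 nM. Compound 2 thus stands second highest of the three: its number and that of compound 3 lie within the scatter of each other, while compound 1 sits clearly above it, as the step of a 3.6-fold lower number from compound 1 to compound 2 (0.56 log units; beyond the scatter) shows.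

Compound 4 `O=C1CC(C(F)(F)F)CN1c1cnn2c1CN(C(=O)Nc1cc(F)c(F)c(F)c1)C(C1CC1)C2` has not yet been measured. It differs from compound 2 in one place: 2-oxo-4-(trifluoromethyl)pyrrolidin-1-yl in place of 2-oxo-4-phenylimidazolidin-1-yl on an aromatic carbon

Among the compounds with values here, two measured steps bear on this change, and both start from compound 1, whose substituent is a pyrrolidinone carrying a 1,3-oxazol-5-yl group: a 3.6-fold lower number from compound 1 to compound 2 (0.56 log units; beyond the scatter) and a 4.3-fold lower number from compound 1 to compound 3 (0.64 log units; beyond the scatter). In each, bringing in a six-membered aromatic ring of carbon only lowered the number by a modest amount. The change to compound 4 takes the phenyl away again and returns to a pyrrolidinone, now carrying a trifluoromethyl group, for which no direct precedent exists among these compounds. As far as these compounds go, a modest rise back toward the number of compound 1 is therefore expected, though the trifluoromethyl group is untested and the estimate is wide. For compound 4 the expected step is a 1.8-fold higher number from compound 2 to compound 4 (0.26 log units; within the scatter). Compound 4 is estimated at 70000 nM, with a range from 30000 nM to 160000 nM.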

Compound 4, half-maximal cytotoxic concentration: 115000 nM
Compound 4: the middle estimate sits 1.6-fold (0.22 log units) below what was measured, within the range that was stated.
By their numbers in this assay, from the lowest: compounds 3 and 2 (each within the scatter of the next); then compounds 4 and 1 (each within the scatter of the next).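

In this assay the trifluoromethyl pyrrolidinone brings the number back up, with a 3.0-fold higher number from compound 2 to compound 4 (0.48 log units; beyond the scatter) and, where only the group on the saturated ring carbon changes, a 3.6-fold higher number from compound 3 to compound 4 (0.55 log units; beyond the scatter) on the same pyrrolidinone. Trifluoromethyl therefore lands level with the 1,3-oxazol-5-yl group, as a 1.2-fold lower number from compound 1 to compound 4 (0.08 log units; within the scatter) shows, so a group with no ring at all can match the oxazole at this carbon. Across these four compounds, the two carrying a six-membered aromatic ring of carbon only, compound 2 and compound 3, have the lower numbers, and no compound shown goes against that; the step from compound 2 also replaces the imidazolidinone ring, however, so it mixes two changes.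

The data shown offer no measured reason for any of these differences. Still open, as far as these compounds go, is whether a methyl, a hydroxyl or an amine on the same saturated ring carbon would keep the number as high as compound 4 does, and whether trifluoromethyl on the imidazolidinone ring would behave as it does on the pyrrolidinone.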